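Methyl in Place of Acetamido on an Inactive Scaffold

The source may hold more compounds than are shown below. What is called first, only, known or untested is meant among the compounds shown, and "the series" means these compounds.

Compound 1 `COc1ccc2nc(-c3ccccc3OCc3ccccc3)sc2c1`: > 50000 nM
Compound 2 `COc1ccc2nc(-c3cccc(NC(C)=O)c3)sc2c1`: > 50000 nM

Both values come from an assay on isolated protein for inhibition of Luciferin 4-monooxygenase (Photuris pensylvanica), read by a luciferase reporter and Kinase-Glo; on this read-out lower numbers stand for stronger inhibition and higher numbers for weaker inhibition. For compound 1 the value is a limit of the assay, not a number. For compound 2 the value is likewise only a limit. Compound 2 therefore stands at the upper edge of what the assay reports, and it is not alone there, as every value shown sits at that same limit (the limit of > 50000 nM in this assay, at which 2 of the 2 values shown sit). Among the measured compounds shown here, with two limits and no number, no step between measured compounds can be drawn, and nothing separates compound 1 from compound 2 beyond the scatter.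

Compound 3 `COc1ccc2nc(-c3cccc(C)c3)sc2c1` has not yet been measured. It differs from compound 2 in one place: methyl in place of acetamido on an aromatic carbon. For the measured compounds named here, no step between measured compounds is known, so the size of the expected step can only rest on the shared limit. Because compound 2 sits at the limit of > 50000 nM in this assay, at which 2 of the 2 values shown sit, no change beyond the scatter is expected in either direction. Compound 3 is expected to give 60000 nM in this assay, with a range from 20000 nM to 200000 nM. That estimate means a step that the limit leaves unreadable from compound 2 to compound 3, which is none beyond the scatter.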

Compound 3, half-maximal inhibitory concentration: > 50000 nM
Compound 3 ended at the assay's limit; the forecaster's own chance of this, stated with the estimate: 80%; the middle value lies beyond the limit too.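

In this assay compound 2 and compound 3 both stand at a limit and not at a number, and no step can be read between them. The compounds shown leave open whether in this assay any change to the shared core gives a number rather than a limit, and what methyl in place of acetamido would do on such a core.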